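A Three-Membered Ring on a Silent Amide

This account rests on a few compounds, and the source may have more. Where it says the series, first, only, none or still open, it means among the compounds named here.

In a functional assay on A2780 cells (Homo sapiens) for antiproliferative activity, read by CellTiter-Glo, with a stated time of 4 days (a lower number here means a stronger inhibitor, a higher number a weaker inhibitor), compound 1 `CC(=O)NCc1ncc2cc(COc3ccc(C(=O)NCc4cccnc4)cc3)n(CCC3CCCCC3)c2n1` gives 15 nM, which shows what strong inhibition looks like on this scale. Compound 2 `O=C(CCc1cccnc1)Nc1ccc(CN2C(=O)c3ccccc3C2=O)cc1` returns only a limit of the assay, > 10000 nM, so it has no exact number.

Compound 3 `O=C(Nc1ccc(CN2C(=O)c3ccccc3C2=O)cc1)[C@H]1C[C@@H]1c1cccnc1` keeps the rest of compound 2 and changes one group on a carbonyl carbon: a group of 9 heavy atoms (8 carbon, 1 nitrogen; one three-membered non-aromatic ring of carbon only, one six-membered aromatic ring with 1 hetero atom) in place of a group of 8 heavy atoms (7 carbon, 1 nitrogen; one six-membered aromatic ring with 1 hetero atom), on a carbonyl carbon. The 2-(pyridin-3-yl)ethyl group leaves, and the entering group carries a three-membered non-aromatic ring of carbon only, along with 2 defined stereocentres. Going by the values given here, no measured pair of compounds shows what such a change does, so the forecast is uncertain.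

Any measurable result in this assay would have to be stronger, since compound 2 stands at the limit > 10000 nM. A large gain is expected, although another limit remains possible. The estimated change is an at least 50-fold lower number from compound 2 to compound 3 (1.69 log units; beyond the scatter). Compound 3 is expected at about 200 nM, with an estimated range of 10 nM to 8000 nM.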

Compound 3, half-maximal inhibitory concentration: 27 nM
Estimate against measurement, compound 3: 7.4-fold (0.87 log units) above, and the stated range covers the measured number.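

The change on this carbonyl carbon is enough on its own to take the amide from the assay limit to an exact value: this assay records an at least 370-fold lower number from compound 2 to compound 3 (2.56 log units; beyond the scatter). Both the leaving and the entering group carry a six-membered aromatic ring with 1 hetero atom, and neither differs in hydrogen-bond donors or acceptors, so what sets them apart is the three-membered ring of carbon only and its 2 defined stereocentres. The step gives only a minimum size, not an exact one, because compound 2 has no exact number: the limit of > 10000 nM in this assay, at which 1 of the 3 values shown sits.

On these data alone, one step cannot separate the contribution of the three-membered ring from that of the particular stereochemistry, so it remains open whether the mirror-image form of the entering group, or a form with its two ring substituents arranged differently, would match compound 3. Also open, as far as these compounds go, is whether this position would accept a cyclobutane ring in place of the three-membered ring, or a phenyl group in place of the pyridin-3-yl ring.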